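A few compounds are considered here, and "the series" means these few. Any claim that something is new, unique, unknown or untested is made for them only; others in the source may bear on it.

Of the compounds shown here, three have so far been measured in an assay on HEK293 cells for agonist activity at transient receptor potential cation channel subfamily M member 8 (Homo sapiens), read by fluorescence and calcium flux, with a stated time of 15 min; on this read-out higher numbers stand for an effect only at larger amounts of compound and lower numbers for an effect already at smaller amounts. Compound 1 `CCCc1ccc(OCC(=O)N(CC)Cc2cccs2)cc1` gives 1810 nM, compound 2 `CCN(Cc1cccs1)C(=O)COc1cc(C)ccc1O` gives 24 nM, and compound 3 `Cc1ccc(/C=C/C(=O)N(Cc2cccs2)c2ccn[nH]2)cc1` gives 0.004 nM. Compound 3 thus has the lowest number of the three, and its gaps to compound 2 and to compound 1 both lie beyond the scatter, so it is the most potent compound of this set in this assay.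

Compound 4 `CCN(Cc1cccs1)C(=O)/C=C/c1ccc(C)cc1` has not yet been measured. It differs from compound 3 in one place: ethyl in place of 1H-pyrazol-5-yl on an amide-type nitrogen. Within the data shown here, no pair of measured compounds differs by exactly this change, so the size of the step cannot be read off directly. Compound 1 and compound 2 both carry an ethyl on the amide-type nitrogen, as compound 4 does, and both sit far above compound 3 in this assay; this is only a loose hint, since they also differ from compound 4 elsewhere. The step is expected to be large and towards higher numbers, a 7500-fold higher number from compound 3 to compound 4 (3.88 log units; beyond the scatter). Compound 4 is therefore estimated at 30 nM, with a range from 0.5 nM to 3000 nM.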

Compound 4, half-maximal effective concentration: 2 nM
Compound 4: the middle estimate sits 15-fold (1.18 log units) above what was measured; measured number inside the range.
By their numbers in this assay, from the lowest: compound 3; then compound 4; then compound 2; then compound 1.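

In this assay, putting ethyl in place of 1H-pyrazol-5-yl on the amide-type nitrogen gives a 500-fold higher number from compound 3 to compound 4 (2.70 log units; beyond the scatter), so this single position has a large effect on the read-out while the rest of the molecule stays the same. The change removes a five-membered aromatic ring with 2 hetero atoms, along with its hydrogen-bond donor and acceptor, and this one pair cannot show which of these features accounts for the step. No measurement shown here explains the size of the step.

As far as these compounds go, what remains open is whether the ring itself matters or the particular atoms in it. A phenyl ring or a longer chain such as propyl on the same nitrogen would help to separate these two possibilities.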